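Anilino variation on the shared core: working notes

The source may hold more compounds than are shown below. What is called first, only, known or untested is meant among the compounds shown, and "the series" means these compounds.

Measured so far in a functional assay on HL-60 cells (Homo sapiens) for cytotoxicity, read by MTT assay, with a stated time of 48 h; on this read-out higher numbers stand for weaker inhibition and lower numbers for stronger inhibition:
compound 1 `COc1ccccc1Nc1nc(-c2cccc(F)c2)nc2ccc(F)cc12` gives > 50000 nM, which is a limit of the assay.
compound 2 `Fc1cccc(-c2nc(Nc3cccc(Br)c3)c3cc(F)ccc3n2)c1` gives > 50000 nM, which is a limit of the assay.

Compound 2 stands at the limit only; no number is available for it in this assay. For the measured compounds named here, the one step between measured compounds, a step that the two limits leave unreadable from compound 1 to compound 2, cannot be read, as both of its ends sit at the limit of > 50000 nM in this assay, at which 2 of the 2 values shown sit.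

Compound 3 `Fc1cccc(-c2nc(Nc3ccccc3Br)c3cc(F)ccc3n2)c1` differs from compound 2 by 2-bromophenyl in place of 3-bromophenyl on a nitrogen on an aromatic ring. Going by the values given here, no measured step bears on this change: the step from compound 1 to compound 2 shows only that a 3-bromophenyl group on that nitrogen stays at the limit and says nothing about a 2-bromophenyl group in the same place. Both values shown sit at the limit of > 50000 nM in this assay, at which 2 of the 2 values shown sit. On these numbers alone compound 3 is expected to remain at the limit as well. For compound 3 the expected step is a number no higher from compound 2 to compound 3 (the limit leaves the size open). Compound 3 is estimated at 50000 nM, within 15000 nM to 150000 nM, and is most likely to be reported again only as a limit.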

Compound 3, half-maximal inhibitory concentration: > 50000 nM
Compound 3 was reported as a limit; the forecaster's own chance of this, stated with the estimate: 75%; the middle value lies on the limit itself.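

In this assay, no step among compound 1, compound 2 and compound 3 can be read, as all three sit at one limit of the assay: the limit of > 50000 nM in this assay, at which 3 of the 3 values shown sit.

The compounds shown leave open whether any group on that nitrogen of the shared core gives a readable value, and how the 2-methoxyphenyl, 3-bromophenyl and 2-bromophenyl groups rank against one another.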